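This account rests on a few compounds, and the source may have more. Where it says the series, first, only, none or still open, it means among the compounds named here.

Compound 1 `CC(C)(C)Cc1cnc(CCc2ccc(-c3ccccc3C(=O)O)cc2)[nH]1` is the starting point. Among the measured compounds shown here, in an in vitro functional assay on cells for agonist activity at Bombesin receptor subtype-3 (Homo sapiens), read by luminescence and calcium flux (on this read-out higher numbers stand for an effect only at larger amounts of compound and lower numbers for an effect already at smaller amounts), compound 1 gives 106 nM, the lowest of the two numbers measured so far. Compound 2 `CCCCc1cnc(CCCc2ccc(-c3ccccc3C(=O)O)cc2)[nH]1` gives 5600 nM in this assay, a gap well beyond the usual scatter. Compound 3 `CC(C)CCc1cnc(CCc2ccc(-c3ccccc3C(=O)O)cc2)[nH]1` has not yet been measured. It keeps every atom of compound 1 but joins them differently: isobutyl in place of tert-butyl on a saturated chain carbon bound to an aromatic carbon. For the measured compounds named here, no measured pair shows this change on its own, so only a modest step is expected in this assay, a 1.9-fold higher number from compound 1 to compound 3 (0.28 log units; within the scatter), leaning toward a somewhat higher number. For compound 3 the estimate is 200 nM, with a range from 60 nM to 700 nM.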

Compound 3, half-maximal effective concentration: 119 nM
The estimate for compound 3 lay 1.7-fold (0.23 log units) above the measured number; low and high end bracket the measured number.
By their numbers in this assay, from the lowest: compounds 1 and 3 (each within the scatter of the next); then compound 2.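

Swapping tert-butyl for isobutyl on a saturated chain carbon bound to an aromatic carbon gives a 1.1-fold higher number from compound 1 to compound 3 (0.05 log units; within the scatter) in this assay and so leaves the read-out effectively unchanged. For this pair, rearranging the same carbon atoms in this branched group therefore has no effect that can be told from the scatter. Nothing measured here explains this result. Compound 2 differs from compound 1 in more than one place, so the source of its much higher number stays unresolved. Going by these compounds, whether an amine or a hydroxyl group in this chain would also be tolerated remains open.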